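The source may report more compounds than this note shows. Statements on the series, on what has been measured and on what is new or still open speak of the compounds shown alone.

Measured so far in a functional assay on HL-60 cells (Homo sapiens) for inhibition, read by CCK-8 assay, with a stated time of 48 h, tested at 20 uM; a lower number here means less inhibition of growth, a higher number more inhibition of growth at the concentration tested:
- compound 1 `COc1ccc(Cc2nnc(NC(=O)/C(C#N)=C/c3ccccc3OS(=O)(=O)c3ccc(Cl)cc3)s2)cc1` gives 20%
- compound 2 `N#C/C(=C\c1ccccc1OS(=O)(=O)c1ccc(Cl)cc1)C(=O)Nc1nnc(Cc2ccc(F)cc2)s1` gives 20%

Within the data shown here, compound 2 stands level with compound 1 on these numbers, with compound 2 at 20% and no measured compound apart from it. The next change gives compound 3 `N#C/C(=C\c1ccccc1OS(=O)(=O)c1ccc(Cl)cc1)C(=O)Nc1nnc(-c2cccc(F)c2)s1` and is 3-fluorophenyl in place of 4-fluorobenzyl on an aromatic carbon, with 3-fluorophenyl in place of 4-fluorobenzyl on an aromatic carbon. Among the measured compounds shown here, only one measured step bears on this, namely no change at the digits printed from compound 1 to compound 2 (within the scatter), a replacement of methoxy by fluoro. For the measured compounds named here, that step leaves the benzyl group in place, so it is only indirect evidence, and no measured compound carries a phenyl group here. With so little to go on, no shift beyond the scatter is expected in this assay, though the uncertainty is wide. The expected change is a number 2 percentage points higher from compound 2 to compound 3 (within the scatter) in this estimate. For compound 3 the estimated value is 22% (expected range 8% to 42%).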

Compound 3, percent growth inhibition at one concentration: 42%
Estimate against measurement, compound 3: 20 percentage points below; the measured number falls inside the stated range.
By their numbers in this assay, from the lowest: compounds 1 and 2 (each within the scatter of the next); then compound 3.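

At the aromatic carbon of the five-membered aromatic ring with 2 nitrogen and 1 sulfur, this assay does respond to the substituent: 3-fluorophenyl in place of 4-fluorobenzyl gives a number 22 percentage points higher from compound 2 to compound 3 (beyond the scatter) and 3-fluorophenyl in place of 4-methoxybenzyl gives a number 22 percentage points higher from compound 1 to compound 3 (beyond the scatter) at this same carbon. The earlier step kept the benzyl group and showed no such separation, whereas this change replaces the benzyl group and alters the place of the fluoro together, so the two contributions cannot be told apart. Nothing available accounts for the rise.

Still open, as far as these compounds go, is whether the rise belongs to the phenyl group itself or to its fluoro, a question that plain phenyl and 4-fluorophenyl would separate. Also open, from the compounds shown here alone, is how a longer chain such as 2-phenylethyl, or an amine, would behave at this carbon.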